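The source may hold more compounds than are shown below. What is called first, only, known or untested is meant among the compounds shown, and "the series" means these compounds.

Values in a functional assay on ECa-109 cells (Homo sapiens) for antiproliferative activity, read by MTT assay, with a stated time of 48 h (on this read-out higher numbers stand for weaker inhibition and lower numbers for stronger inhibition), follow.
- compound 1 `Cn1cc(C2=C(c3nn(CCCn4cncn4)c4ncccc34)C(=O)NC2=O)c2ccccc21` gives > 100000 nM (a limit)
- compound 2 `Cn1cc(C2=C(c3nn(CCCn4ccnc4)c4ncccc34)C(=O)NC2=O)c2ccccc21` gives > 100000 nM (a limit)
- compound 3 `CN(C)CCCn1nc(C2=C(c3cn(C)c4ccccc34)C(=O)N(c3ccccc3)C2=O)c2cccnc21` gives 5840 nM

Going by the values given here, compound 3 holds the only number here, the other two values being limits. Compound 4 `CN(C)CCCn1nc(C2=C(c3cn(C)c4ccccc34)C(=O)NC2=O)c2cccnc21` differs from it by hydrogen in place of phenyl on an amide-type nitrogen in a ring. Among the compounds with values here, no measured step touches this place: a step that the two limits leave unreadable from compound 1 to compound 2 lies elsewhere and its size cannot be read. Compound 1 bears hydrogen on that nitrogen and gives > 100000 nM as a limit. Compound 2 also bears hydrogen there and gives > 100000 nM as a limit. Both differ from compound 4 elsewhere too, so this is weak guidance. A modest, uncertain move toward weaker inhibition is expected, as the estimated 1.7-fold higher number from compound 3 to compound 4 (0.23 log units; within the scatter) in this assay shows. Compound 4 is estimated at 10000 nM (expected range 2000 nM to 50000 nM).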

Compound 4, half-maximal inhibitory concentration: > 100000 nM
Compound 4: a limit, no number (the forecaster's own chance of this, stated with the estimate: 15%); middle value at least 10-fold (1.00 log units) away from the limit.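

In this assay, going by these compounds alone, the amide-type nitrogen in a ring proves sensitive to its substituent: hydrogen in place of phenyl gives an at least 17-fold higher number from compound 3 to compound 4 (1.23 log units; beyond the scatter), the only readable step. From the compounds shown here alone, compound 4 gives > 100000 nM, a limit and not a number, so the full size of this step stays open, and compound 4 joins the floor of the series: the limit of > 100000 nM in this assay, at which 3 of the 4 values shown sit. The steps among compound 1, compound 2 and compound 4 cannot be read. Open, going by these compounds, is whether methyl or benzyl on that nitrogen retains the value of compound 3. Also open, on these data alone, is whether phenyl there would bring a readable number with the 1H-imidazol-1-yl or 1H-1,2,4-triazol-1-yl chains.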